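The source may report more compounds than this note shows. Statements on the series, on what has been measured and on what is new or still open speak of the compounds shown alone.

Measured in a functional assay on MKN-45 cells (Homo sapiens) for inhibition, with a stated time of 72 h; a higher number here means a weaker inhibitor, a lower number a stronger inhibitor:
Compound 1 `COc1cc(C(=O)c2ccc3c(ccn3CO)c2)cc(OC)c1OC`: 33 nM
Compound 2 `COc1cc(C(=O)c2ccc3c(ccn3CCC(=O)O)c2)cc(OC)c1OC`: > 10000 nM (a limit of the assay)

Compound 2 gives > 10000 nM, which is a limit of the assay and not a number. It stands at the limit of > 10000 nM in this assay, at which 1 of the 2 values shown sits. Compound 3 `COc1cc(C(=O)c2ccc3c(ccn3CCN(C)C)c2)cc(OC)c1OC` keeps the shared core and differs from compound 2 in one place: dimethylamino in place of carboxy on a saturated chain carbon, two bonds along the chain from an aromatic nitrogen. In words, this is dimethylamino in place of carboxy on a saturated chain carbon, two bonds along the chain from an aromatic nitrogen.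

Going by the values given here, one measured step bears on this change: an at least 300-fold higher number from compound 1 to compound 2 (2.48 log units; beyond the scatter). That step is large and brought in the carboxy group, which now leaves. The expectation is therefore that compound 3 recovers much of that loss in this assay, though perhaps not all the way back to compound 1 at 33 nM. Among the compounds with values here, no measured compound carries dimethylamino, so the size of the recovery is uncertain. The expected change, a large one towards a lower number, is an at least 33-fold lower number from compound 2 to compound 3 (1.52 log units; beyond the scatter). For compound 3 the estimate is 300 nM, with an expected range from 40 nM to 3000 nM.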

Compound 3, half-maximal inhibitory concentration: 2900 nM
For compound 3 the middle estimate is 9.7-fold (0.99 log units) below the measured one, and the stated range covers the measured number.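

In this assay, putting dimethylamino in place of carboxy gives an at least 3.4-fold lower number from compound 2 to compound 3 (0.53 log units; beyond the scatter), so this chain can carry a group other than carboxy and still return a measurable value. The value of compound 2 is a limit and not a number, so only a minimum can be stated for the size of this step: the limit of > 10000 nM in this assay, at which 1 of the 3 values shown sits. The recovery is only partial, however, with an 88-fold higher number from compound 1 to compound 3 (1.94 log units; beyond the scatter), so removing the carboxy group does not by itself bring back the strength of compound 1.

The compounds shown leave open whether the gap to compound 1 follows from the end group, from the length of the chain, or from both, since compound 1 and compound 3 differ in both at once within their single changed place. A 2-hydroxyethyl chain on the same core would help to separate these two, while a primary amine or an amide at the end of the 2-carbon chain would show whether dimethylamino is the best replacement for carboxy here.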